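Changing one group on compound 2

The source may report more compounds than this note shows. Statements on the series, on what has been measured and on what is new or still open speak of the compounds shown alone.

Within the data shown here, in a functional assay on P388 cells (Mus musculus) (a higher number here means a weaker inhibitor, a lower number a stronger inhibitor), compound 2 `Cc1ccc(/C=C/C(=O)Oc2ccc(/C=C3\CCCC(CN(C)C)C3=O)cc2)cc1` gives 1290 nM and holds the lowest number so far. Compound 3 `O=C1CCCC/C1=C\c1ccc(OC(=O)c2ccc(Cl)cc2)cc1` gives 25500 nM and lies well beyond the scatter from it. Compound 1 `O=C(/C=C/c1ccc(Cl)c(Cl)c1)Oc1ccc(/C=C2\CCCCC2=O)cc1` shows > 50000 nM as a limit of the assay and not a number. Among the measured compounds shown here, compound 4 `COc1ccc(C(=O)Oc2ccc(/C=C3\CCCC(CN(C)C)C3=O)cc2)cc1` keeps the rest of compound 2 and carries 4-methoxyphenyl in place of 2-(4-methylphenyl)ethenyl on a carbonyl carbon as its single change. For the measured compounds named here, no measured pair shows this exchange, so this assay is expected to show a small step toward a higher number, perhaps no larger than the scatter. The estimate amounts to a 1.6-fold higher number from compound 2 to compound 4 (0.19 log units; within the scatter) in this reading. Compound 4 is expected at 2000 nM with an estimated range from 600 nM to 7000 nM in this measurement.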

Compound 4, half-maximal inhibitory concentration: 332 nM
Compound 4: middle estimate off by 6.0-fold (0.78 log units), on the high side, outside the stated range (below it).
By their numbers in this assay, from the lowest: compound 4; then compound 2; then compound 3. At a limit, above all of these: compound 1.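

In this assay, the place on a carbonyl carbon turns out to respond to a single exchange: 4-methoxyphenyl in place of 2-(4-methylphenyl)ethenyl gives a 3.9-fold lower number from compound 2 to compound 4 (0.59 log units; beyond the scatter) and so a stronger inhibitor. Among these compounds, this is the first pair differing in one place, and it shows that the 2-(4-methylphenyl)ethenyl group is not required for inhibition here. Open, on these data alone, is whether the methoxy group or the loss of the double bond carries this step, and whether a 4-aminophenyl or 4-carboxyphenyl group at this place would follow it. Nothing measured here explains the step.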